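Replacing the nitrile on the core with an aryl group

The source may hold more compounds than are shown below. What is called first, only, known or untested is meant among the compounds shown, and "the series" means these compounds.

In an ADME assay on cells (Hepatocyte, Rattus norvegicus) for metabolic stability, with a stated time of 90 min (on this read-out higher numbers stand for fast clearance and lower numbers for slow clearance), three compounds of the series carry numbers. Compound 1 `CCC(CC)CNc1c(C(N)=O)cnc2ccc(C#N)cc12` gives 74 uL/min. Compound 2 `C[C@@H](Nc1c(C(N)=O)cnc2ccc(C#N)cc12)c1ccc(Cl)cc1` gives 41 uL/min, and compound 3 `C[C@H](Nc1c(C(N)=O)cnc2ccc(-c3cccnc3)cc12)C1CCOCC1` gives 38 uL/min. Compound 1 sits at the top of the three numbers, yet its gaps to compound 2 and to compound 3 both fall within the usual scatter, so on this assay the three are not told apart. No pair among them differs in a single place, so no single step is shown for the series.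

Compound 4 `CCC(CC)CNc1c(C(N)=O)cnc2ccc(-c3ccc(COC)cc3)cc12` is not yet measured. It differs from compound 1 in one place: 4-(methoxymethyl)phenyl in place of cyano on an aromatic carbon. A group with a ring enters where cyano, without a ring, leaves. No step of this kind is shown among the measured compounds, so the expectation rests on compound 1 alone: a modest rise in the number, quite possibly within the scatter. The step is estimated as a 1.4-fold higher number from compound 1 to compound 4 (0.13 log units; within the scatter). Compound 4 is expected to give 100 uL/min, within 50 uL/min to 200 uL/min.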

Compound 4, intrinsic clearance in a liver preparation (reported as CLH), per the amount of preparation that the assay uses: 76 uL/min
For compound 4 the middle estimate is 1.3-fold (0.12 log units) above the measured one; the range from low to high includes it.
By their numbers in this assay, from the lowest: compounds 3, 2, 1 and 4 (each within the scatter of the next).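

On the shared core, the aromatic carbon that carries cyano in compound 1 now has a direct comparison in this assay: 4-(methoxymethyl)phenyl in place of cyano gives a 1.0-fold higher number from compound 1 to compound 4 (0.01 log units; within the scatter) and leaves the two compounds not told apart. A group of 9 heavy atoms with a six-membered aromatic ring thus stands where a group of 2 heavy atoms without a ring stood, with the rest of compound 1 held fixed. Nothing at hand bears on what lies behind this result.

Open, on these data alone, is how a carboxylic acid or an aminomethyl group in place of the methoxymethyl on that phenyl would read in this assay. Also open, as far as these compounds go, is whether the same replacement of cyano reads alike with the side chain of compound 2.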